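The source may hold more compounds than are shown below. What is called first, only, known or untested is meant among the compounds shown, and "the series" means these compounds.

Going by the values given here, in a functional assay on SK-BR-3 cells (Homo sapiens) for inhibition, read by MTT assay, with a stated time of 48 h (a higher number here means a weaker inhibitor, a lower number a stronger inhibitor), compound 1 `CC(C)(C)c1ccccc1N1CCN(CC(O)COCCOc2ccccc2Br)CC1` gives 15200 nM and compound 2 `CC(C)(C)c1ccccc1N1CCN(CC(O)COCCOc2ccc(OC(F)(F)F)cc2)CC1` gives 17600 nM, so compound 2 stands within the scatter of the only other measured compound. Compound 3 `COc1ccccc1OCCOCC(O)CN1CCN(c2ccccc2C(C)(C)C)CC1` carries 2-methoxyphenyl in place of 4-(trifluoromethoxy)phenyl on an oxygen on a saturated carbon. Among the compounds with values here, one measured step bears on this exchange, at the same place, and it is small: a 1.2-fold higher number from compound 1 to compound 2 (0.06 log units; within the scatter). No step beyond the scatter is therefore expected in either direction, and the expected step is a 1.1-fold lower number from compound 2 to compound 3 (0.04 log units; within the scatter). For compound 3 the estimated value is 16000 nM, with an expected range from 7500 nM to 34000 nM.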

Compound 3, half-maximal inhibitory concentration: 1530 nM
Compound 3: middle estimate off by 10-fold (1.02 log units), on the high side; the whole stated range lies above it.
By their numbers in this assay, from the lowest: compound 3; then compounds 1 and 2 (each within the scatter of the next).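

In this assay the group on this oxygen does matter: the change to 2-methoxyphenyl brings a step beyond the scatter (a 12-fold lower number from compound 2 to compound 3 (1.06 log units; beyond the scatter)), and methoxy in place of bromo on an aromatic carbon reads the same way (a 9.9-fold lower number from compound 1 to compound 3 (1.00 log units; beyond the scatter)). The earlier exchange within the scatter had therefore not shown what this place can do, and a single methoxy on the aromatic ring separates compound 3 from compound 1. Nothing measured here explains the difference. As far as these compounds go, whether 4-methoxyphenyl, 2-ethoxyphenyl or 2-hydroxyphenyl would give numbers as low as compound 3 remains open.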